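Trifluoromethoxy for Fluoro on Two Quinazolinone Cores

The compounds below may be only part of what the source reports. "The series", "measured", "known", "first", "only" and "open" are said of these compounds alone.

Compound 1, `Cc1ccc2c(=O)[nH]c(-c3ccccc3OC(F)(F)F)nc2c1`: 15900 nM
Compound 2, `Cc1ccc2c(=O)[nH]c(-c3ccccc3F)nc2c1`: 10300 nM
Compound 3, `Cc1ccc2nc(-c3cccc(F)c3)[nH]c(=O)c2c1`: > 50000 nM

Of the compounds shown here, three have been measured in a functional assay on HCT-15 cells (Homo sapiens) for cytotoxicity, read by MTT assay, with a stated time of 2 days; on this read-out lower numbers stand for stronger inhibition and higher numbers for weaker inhibition. Compound 1 and compound 2 share one core and differ by trifluoromethoxy in place of fluoro on an aromatic carbon; the step was a 1.5-fold higher number from compound 2 to compound 1 (0.19 log units; within the scatter). Compound 3 is built from the same atoms as compound 2, joined differently, and the difference between the two cores is not broken down here. The value of compound 3 in this assay is a limit of the assay and not a number, and it sits at the limit of > 50000 nM in this assay, at which 1 of the 3 values shown sits.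

Compound 4 `Cc1ccc2nc(-c3cccc(OC(F)(F)F)c3)[nH]c(=O)c2c1` has not yet been measured. It differs from compound 3 by trifluoromethoxy in place of fluoro on an aromatic carbon. This is the same kind of change as that from compound 2 to compound 1, though not the same: in compound 1 the new group stands ortho to a large group, in compound 4 it stands meta to a large group.

The step from compound 3 to compound 4 in this assay is expected to be a step that the limit leaves unreadable from compound 3 to compound 4; this expectation rests on the step of a 1.5-fold higher number from compound 2 to compound 1 (0.19 log units; within the scatter), which stayed within the scatter, and on compound 3 sitting at the limit of > 50000 nM in this assay, at which 1 of the 3 values shown sits. Compound 4 is therefore estimated at 70000 nM, with a range from 20000 nM to 250000 nM, and it is expected that this assay will most likely again report only a limit for compound 4.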

Compound 4, half-maximal inhibitory concentration: > 50000 nM
Compound 4: no number, only a limit; the forecaster's own chance of this, stated with the estimate: 75%; the middle value lies beyond the limit too.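

Like compound 3, compound 4 gives no number in this assay, and no step can be read between the two compounds because both stand at the same limit of the assay: the limit of > 50000 nM in this assay, at which 2 of the 4 values shown sit.

The compounds shown leave open whether trifluoromethoxy in place of fluoro changes the read-out at all on the core of compound 3, and how far past the limit either compound lies.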